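The source may hold more compounds than are shown below. What is called first, only, known or untested is meant among the compounds shown, and "the series" means these compounds.

For the measured compounds named here, in a functional assay on L1210 cells (Mus musculus) for inhibition (a lower number here means a stronger inhibitor, a higher number a weaker inhibitor), compound 1 `C=CCN(Cc1ccc2nc(C)[nH]c(=O)c2c1)c1ccc(C(=O)N[C@@H](CCC(=O)O)C(=O)O)cc1F` gives 140 nM as the lower of the two numbers so far, while compound 2 `CCN(Cc1ccc2nc(C)[nH]c(=O)c2c1)c1ccc(C(=O)N[C@@H](CCC(=O)O)C(=O)O)c(Cl)c1` gives 870 nM in the same read-out. Going by the values given here, no step between measured compounds isolates the group on the nitrogen, so the next expectation rests on the structural change alone. Compound 3 `C#CCN(Cc1ccc2nc(C)[nH]c(=O)c2c1)c1ccc(C(=O)N[C@@H](CCC(=O)O)C(=O)O)cc1F` carries ethynyl in place of vinyl on a saturated chain carbon bound to a nitrogen on an aromatic ring, which is allyl to propargyl. In this assay a modest step toward a lower number is expected, close to the edge of the scatter. The expected change is a 1.9-fold lower number from compound 1 to compound 3 (0.27 log units; within the scatter) as an estimate only. The estimated value for compound 3 is 75 nM with an expected range from 25 nM to 220 nM as the likely span.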

Compound 3, half-maximal inhibitory concentration: 52 nM
Compound 3: middle estimate off by 1.4-fold (0.16 log units), on the high side; the range from low to high includes it.
By their numbers in this assay, from the lowest: compound 3; then compound 1; then compound 2.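

Ethynyl in place of vinyl on a saturated chain carbon bound to a nitrogen on an aromatic ring gives, in this assay, a 2.7-fold lower number from compound 1 to compound 3 (0.43 log units; beyond the scatter) and thus the first single-change reading at this position. The read-out responds here to a triple bond replacing a double bond, with the count of heavy atoms unchanged. Nothing available explains this step.

Open, on these data alone, is how a saturated propyl group or a longer chain ending in a triple bond, such as but-2-ynyl, would read at this position.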